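Chloro for hydrogen on the aromatic ring: the next step

A few compounds are considered here, and "the series" means these few. Any claim that something is new, unique, unknown or untested is made for them only; others in the source may bear on it.

Measured so far:
- compound 1 `Cc1cc(N2CC[C@@H]3CN[C@@H]3C2)cnc1Cl`; in a functional assay on HEK293 cells for agonist activity at Neuronal acetylcholine receptor; alpha4/beta2 (Homo sapiens), read by FLIPR (on this read-out higher numbers stand for an effect only at larger amounts of compound and lower numbers for an effect already at smaller amounts), compound 1 gives 47 nM
- compound 2 `Cc1cncc(N2CC[C@@H]3CN[C@@H]3C2)c1`; compound 2 gives 650 nM
- compound 3 `c1cncc(N2C[C@@H]3CCNC[C@@H]32)c1`; compound 3 gives 410 nM

One counted step is known within the set: a 14-fold lower number from compound 2 to compound 1 (1.14 log units; beyond the scatter), the change being (chloro in place of hydrogen on an aromatic carbon). Compound 3 lies close to compound 2 in value; the difference between the two cores is not broken down here.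

Compound 4 `Clc1ccc(N2C[C@@H]3CCNC[C@@H]32)cn1` is not yet measured and differs from compound 3 by chloro in place of hydrogen on an aromatic carbon. This is the same kind of change as from compound 2 to compound 1, not the same: in the earlier pair the place is also ortho to a methyl group (1 heavy atom), which compound 4 lacks. Because a 14-fold lower number from compound 2 to compound 1 (1.14 log units; beyond the scatter) was obtained with that methyl group present, a somewhat smaller step is expected here, a 7.5-fold lower number from compound 3 to compound 4 (0.87 log units; beyond the scatter). For compound 4 the estimate is 55 nM, expected to fall between 20 nM and 160 nM.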

Compound 4, half-maximal effective concentration: 37.4 nM
For compound 4 the middle estimate is 1.5-fold (0.17 log units) above the measured one, and the stated range covers the measured number.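

In this assay, chloro in place of hydrogen on an aromatic carbon gives an 11-fold lower number from compound 3 to compound 4 (1.04 log units; beyond the scatter). Set beside the earlier step, the size of the change carries over from one core to the other, and the two steps cannot be told apart: the same change on two cores in this assay, a 14-fold lower number (1.14 log units; beyond the scatter) from compound 2 to compound 1 and an 11-fold lower number (1.04 log units; beyond the scatter) from compound 3 to compound 4, 1.3-fold (0.10 log units) apart, within the scatter of two such steps. Within the data shown here, this rests on only two pairs, which differ both in core and in the methyl group of the earlier pair, so it does not separate those two differences or show that the step would hold on a further core.

Still open, as far as these compounds go, is whether fluoro, bromo, methoxy or a nitrile in the place of the chloro would give a step of like size. An amine or a longer chain there also remains untested in the compounds shown.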